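Chloroquinoline piperazine hydrazones: cytotoxicity on splenocytes

This account rests on a few compounds, and the source may have more. Where it says the series, first, only, none or still open, it means among the compounds named here.

Two members of this series have been tested in an ADME assay on cells (Splenocyte, Mus musculus, strain BALB/c) for cytotoxicity, read by thymidine incorporation, with a stated time of 24 h; on this read-out lower numbers stand for stronger inhibition and higher numbers for weaker inhibition. Compound 1 `COc1cc(/C=N/NC(=O)CCN2CCN(c3ccnc4cc(Cl)ccc34)CC2)ccc1O` gives 9400 nM in this assay. Compound 2 `O=C(CCN1CCN(c2ccnc3cc(Cl)ccc23)CC1)N/N=C/c1ccccc1Cl` gives 10800 nM in this assay. Among the compounds with values here, the only step recorded between them is a 1.1-fold higher number from compound 1 to compound 2 (0.06 log units; within the scatter), so compound 2 stands alongside compound 1 with no separation beyond the scatter; the two numbers are not distinguished by this measurement.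

Compound 3 `O=C(CCN1CCN(c2ccnc3cc(Cl)ccc23)CC1)N/N=C/c1cccc(Cl)c1` is the next member. It differs from compound 2 as follows: 3-chlorophenyl in place of 2-chlorophenyl on a carbon with a double bond to nitrogen. Both compounds carry the same atoms, joined differently, and the change sits on the carbon with a double bond to nitrogen.

Within the data shown here, no measured step bears directly on this change; the one step known, from compound 1 to compound 2, swaps a 4-hydroxy-3-methoxyphenyl for a 2-chlorophenyl and lies within the scatter. Given how little that larger swap moved the read-out, the step of a 1.1-fold lower number from compound 2 to compound 3 (0.03 log units; within the scatter) is expected to stay within the scatter as well, with no particular direction. Compound 3 is therefore estimated at 10000 nM in this assay, with a range from 5000 nM to 20000 nM.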

Compound 3, half-maximal inhibitory concentration: > 100000 nM
Compound 3: only a limit was reported (the forecaster's own chance of this, stated with the estimate: 10%); middle value at least 10-fold (1.00 log units) away from the limit.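

Within the data shown here, the series now holds a clear sensitivity at this place: with the atoms unchanged, 3-chlorophenyl in place of 2-chlorophenyl on a carbon with a double bond to nitrogen gives an at least 9.2-fold higher number from compound 2 to compound 3 (0.96 log units; beyond the scatter) in this assay, the first step to pass the scatter. The value for compound 3 is a limit of the assay and not a number: the limit of > 100000 nM in this assay, at which 1 of the 3 values shown sits. The aryl group here is therefore not interchangeable, as the earlier pair suggested: a 1.1-fold higher number from compound 1 to compound 2 (0.06 log units; within the scatter), yet an at least 10-fold higher number from compound 1 to compound 3 (1.02 log units; beyond the scatter), so among these three compounds the 3-chlorophenyl alone stands apart, while 2-chlorophenyl and 4-hydroxy-3-methoxyphenyl remain together within the scatter.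

As far as these compounds go, the full size of both new steps stays open, since they rest on a limit, and the three compounds do not tell whether the separation belongs to chlorine at this ring position or to the 3-chlorophenyl group alone. Unsubstituted phenyl, 3-bromophenyl or 3-methoxyphenyl on the same carbon would separate these readings, and nothing here says why the two chlorophenyl isomers part so sharply.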